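Methylsulfanyl in Place of Methylamino: An Expected Step

The source may hold more compounds than are shown below. What is called first, only, known or untested is meant among the compounds shown, and "the series" means these compounds.

Compounds measured so far:
compound 1 `Nc1nc(=O)ccn1[C@@H]1O[C@H](COP(=O)(O)OP(=O)(O)O)[C@@H](O)[C@H]1O` with 604 nM
compound 2 `CNc1nc(=O)ccn1[C@@H]1O[C@H](COP(=O)(O)O)[C@@H](O)[C@H]1O` with > 100000 nM
compound 3 `CCCSc1nc(=O)ccn1[C@@H]1O[C@H](COP(=O)(O)OP(=O)(O)O)[C@@H](O)[C@H]1O` with 1200 nM

In an in vitro functional assay on 1321-N1 cells for agonist activity at P2Y purinoceptor 2 (Homo sapiens), read by scintillation proximity assay and inositol phosphate accumulation (on this read-out lower numbers stand for an effect already at smaller amounts and higher numbers for an effect only at larger amounts of compound), compound 1 gives 604 nM and compound 3 gives 1200 nM. Compound 2 gives only a limit in this assay, > 100000 nM, so no number stands for it; it sits at the limit of > 100000 nM in this assay, at which 1 of the 3 values shown sits.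

Compound 4 `CSc1nc(=O)ccn1[C@@H]1O[C@H](COP(=O)(O)O)[C@@H](O)[C@H]1O` has not yet been measured. It differs from compound 2 in one place: methylsulfanyl in place of methylamino on an aromatic carbon. Among the measured compounds shown here, the only measured step that bears on this change is a 2.0-fold higher number from compound 1 to compound 3 (0.30 log units; within the scatter), where an amino group on the same kind of ring carbon gave way to a larger sulfanyl group on a related pair of compounds. That step stayed within the scatter. Accordingly no change beyond the scatter is expected from the exchange of methylamino for methylsulfanyl, and compound 4 is expected to remain where compound 2 stands, at the limit of this assay rather than at a number.

The estimate for compound 4 is therefore 100000 nM, with a range from 30000 nM to 300000 nM, which corresponds to an expected step of a number no higher from compound 2 to compound 4 (the limit leaves the size open).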

Compound 4, half-maximal effective concentration: 2900 nM
The estimate for compound 4 lay 34-fold (1.54 log units) above the measured number; measured number outside the range, below it.
By their numbers in this assay, from the lowest: compounds 1 and 3 (each within the scatter of the next); then compound 4. At a limit, above all of these: compound 2.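

In this assay, methylsulfanyl in place of methylamino on the aromatic carbon between two ring nitrogen atoms gave an at least 34-fold lower number from compound 2 to compound 4 (1.53 log units; beyond the scatter), so on this pair the exchange reaches well beyond the scatter. The earlier step with amino and propylsulfanyl at the same kind of carbon, a 2.0-fold higher number from compound 1 to compound 3 (0.30 log units; within the scatter), stayed within the scatter, and it therefore did not carry over to this pair. The true size of the new step remains unknown because compound 2 gives only a limit and not a number: the limit of > 100000 nM in this assay, at which 1 of the 4 values shown sits.

The compounds shown leave open how an ethylsulfanyl chain, a dimethylamino group or a hydroxyl group would read at this carbon. They also leave open whether methylamino and methylsulfanyl would differ as widely on the core of compound 1.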